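This account rests on a few compounds, and the source may have more. Where it says the series, first, only, none or still open, it means among the compounds named here.

Compound 1, `Nc1ccc2cccc(OCCC(F)(F)F)c2n1`, gives 722 nM in an assay on cells with melanin-concentrating hormone receptor 1 (Homo sapiens) as the target, read by radioligand binding; a lower number here means a stronger inhibitor, a higher number a weaker inhibitor.
Compound 2, `CC(C)OCCOc1cccc2ccc(N)nc12`, reaches only the assay limit of > 2000 nM in this assay.
Compound 3, `CCC#CCOc1cccc2ccc(N)nc12`, likewise reaches only the assay limit of > 2000 nM in this assay.

Compound 3 therefore stands at the weak end of what has been measured, at the limit of > 2000 nM in this assay, at which 2 of the 3 values shown sit. Only compound 1 has a true number; the swap of its 2,2,2-trifluoroethyl group for a but-1-yn-1-yl group weakens binding, as an at least 2.7-fold higher number from compound 1 to compound 3 (0.44 log units; beyond the scatter) shows. The step that the two limits leave unreadable from compound 2 to compound 3 cannot be read, since both compounds sit at the limit.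

The next compound, compound 4, `CSCCOc1cccc2ccc(N)nc12`, carries the change ((methylsulfanyl)methyl in place of but-1-yn-1-yl on a saturated chain carbon bound to an oxygen on an aromatic ring). Within the data shown here, no measured step involves a (methylsulfanyl)methyl group, so the closest guide is that compound 1 alone gave a number and both other variants of this side chain stayed at the limit. Compound 4 is expected to remain weak, with a step that the limit leaves unreadable from compound 3 to compound 4 as the estimated step, and its value in this assay is estimated at 2500 nM, within roughly 800 nM to 8000 nM.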

Compound 4, half-maximal inhibitory concentration: > 2000 nM
Compound 4: a limit, no number (the forecaster's own chance of this, stated with the estimate: 55%); the middle value does not contradict the limit.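

Replacing trifluoromethyl with methylsulfanyl on this side chain also weakens binding in this assay, with an at least 2.7-fold higher number from compound 1 to compound 4 (0.44 log units; beyond the scatter). A sulfur-bearing chain now joins the ether and alkyne chains at the limit, so compound 1 remains the only one of the four with a true number: the limit of > 2000 nM in this assay, at which 3 of the 4 values shown sit. The steps among compound 2, compound 3 and compound 4 cannot be read, as all three values are limits.

As far as these compounds go, how much these three compounds differ from one another therefore remains unknown, as does whether any of them binds measurably at all. Also open, from the compounds shown here alone, is how binding would respond to a longer chain ending in trifluoromethyl or to a chain ending in an amine, either of which would test how specific the result for compound 1 is.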